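Cyclohexyl to 3-(Trifluoromethoxy)phenyl on the Core Nitrogen

A few compounds are considered here, and "the series" means these few. Any claim that something is new, unique, unknown or untested is made for them only; others in the source may bear on it.

Measured compounds:
- compound 1, `Nc1ccccc1NC(=O)/C=C/c1ccc(Cn2cnc3c(NC4CCCCC4)nc(Cl)nc32)cc1`: 42.7%
- compound 2, `CCCCn1cnc2c(Nc3ccccc3)nc(NCOCc3ccc(/C=C/C(=O)Nc4ccccc4N)cc3)nc21`: 59.3%
- compound 3, `CC(C)n1cnc2c(Nc3cccc(Cl)c3)nc(NCOCc3ccc(/C=C/C(=O)Nc4ccccc4N)cc3)nc21`: 49.9%

In a functional assay on HepG2 cells (Homo sapiens) for antiproliferative activity, read by CCK-8 assay, with a stated time of 72 h, tested at 8 uM (a lower number here means a weaker effect, a higher number a stronger effect of the compound at the concentration tested), compound 1 gives 42.7%, the lowest of the three numbers. Compound 3 gives 49.9%, which lies within the scatter of compound 1. Compound 2 gives 59.3%, beyond the scatter above compound 1. Going by the values given here, compounds 2 and 3 differ from compound 1 in several places at once, so no single step between them can be read.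

Compound 4, `Nc1ccccc1NC(=O)/C=C/c1ccc(Cn2cnc3c(Nc4cccc(OC(F)(F)F)c4)nc(Cl)nc32)cc1`, has not yet been measured. It differs from compound 1 in one place: 3-(trifluoromethoxy)phenyl in place of cyclohexyl on a nitrogen on an aromatic ring. The two arylamino compounds 2 and 3 both carry an aromatic ring on the corresponding nitrogen, and compound 2 lies beyond the scatter above compound 1 while compound 3 lies within it. Both also differ from compound 1 elsewhere, so the change alone cannot be tied to a direction with confidence. Compound 4 is therefore expected to show a small step upward, a number 7.3 percentage points higher from compound 1 to compound 4 (within the scatter), close to the edge of the scatter. The estimate for compound 4 in this assay is 50%, with a range from 36% to 64%.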

Compound 4, a percentage reported as inhibition, at one concentration (the size of the read-out at that concentration, not a potency): 37.6%
The estimate for compound 4 lay 12.4 percentage points above the measured number; measured number inside the range.
By their numbers in this assay, from the lowest: compounds 4, 1, 3 and 2 (each within the scatter of the next, the first and the last beyond it).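

In this assay, going by these compounds alone, the exchange of cyclohexyl for 3-(trifluoromethoxy)phenyl on this nitrogen gives the first step that can be read at this position: a number 5.1 percentage points lower from compound 1 to compound 4 (within the scatter). A six-membered non-aromatic ring of carbon and a six-membered aromatic ring bearing trifluoromethoxy are therefore not told apart by this read-out, even though the entering group brings more heavy atoms and a hydrogen-bond acceptor. No measurement at hand offers an explanation of this step.

The compounds shown leave open whether a plain phenyl, a methyl or a phenyl ring bearing a carboxylic acid on this nitrogen would give a step beyond the scatter. They also leave open whether the same exchange would read alike if an amine replaced the chlorine on the shared core.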